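Moving a hydroxyl group on a three-ring scaffold

A few compounds are considered here, and "the series" means these few. Any claim that something is new, unique, unknown or untested is made for them only; others in the source may bear on it.

Of the compounds shown here, three built on a shared core have been measured in an assay on isolated protein for inhibition of DNA topoisomerase 1 (Homo sapiens), with a stated time of 30 min, tested at 100 uM; a higher number here means a stronger effect of the compound at the concentration tested, a lower number a weaker effect. Compound 1 `Oc1cccc(-c2cc(-c3ccsc3)cc(-c3cccc(O)c3)n2)c1` gives 59.2%. Compound 2 `Oc1cccc(-c2cc(-c3ccco3)cc(-c3cccc(O)c3)n2)c1` carries a furan-2-yl in place of the thiophen-3-yl of compound 1. Compound 2 gives 97.8%; that single change is a number 38.6 percentage points higher from compound 1 to compound 2 (beyond the scatter). Compound 3 `Oc1cccc(-c2cc(-c3ccccn3)cc(-c3ccccc3O)n2)c1` gives 35.4%, the lowest of the three numbers, standing clearly apart from compound 1 and further still from compound 2, both gaps beyond the usual scatter.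

Compound 4 `Oc1cccc(-c2cc(-c3ccccn3)cc(-c3cccc(O)c3)n2)c1` is the next compound to be tested. It differs from compound 3 in one respect: 3-hydroxyphenyl in place of 2-hydroxyphenyl on an aromatic carbon. Compound 4 therefore carries two 3-hydroxyphenyl groups, as compound 1 and compound 2 do, while keeping the pyridin-2-yl group of compound 3.

For the measured compounds named here, no measured step concerns this change. Going by the values given here, the only measured step, from compound 1 to compound 2, swaps the third group rather than a hydroxyphenyl, so it offers no direct guide. Compound 1 and compound 2 show that two 3-hydroxyphenyl groups can go with moderate or near-complete inhibition, so the expectation for compound 4 is a rise of a number 19.6 percentage points higher from compound 3 to compound 4 (beyond the scatter), held loosely. Compound 4 is estimated to give 55%, expected to fall between 30% and 85%.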

Compound 4, a percentage reported as inhibition, at one concentration (the size of the read-out at that concentration, not a potency): 8.3%
The estimate for compound 4 lay 46.7 percentage points above the measured number; the measured number lies below the stated range.
By their numbers in this assay, from the lowest: compound 4; then compound 3; then compound 1; then compound 2.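

In this assay, moving the hydroxyl so that 3-hydroxyphenyl replaces 2-hydroxyphenyl, on the carbon next to the ring nitrogen, gives a number 27.1 percentage points lower from compound 3 to compound 4 (beyond the scatter) even though the two compounds have the same atoms, so where the hydroxyl sits matters here and not merely that it is present. Compound 4 also shows that two 3-hydroxyphenyl groups do not bring strong inhibition on their own: pyridin-2-yl in place of furan-2-yl gives a number 89.5 percentage points lower from compound 2 to compound 4 (beyond the scatter) and pyridin-2-yl in place of thiophen-3-yl gives a number 50.9 percentage points lower from compound 1 to compound 4 (beyond the scatter) with both hydroxyphenyl groups unchanged, so among these compounds the third group has a large say in the result. Nothing available explains why either change has the effect it does.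

As far as these compounds go, whether 2-hydroxyphenyl would also give a higher number than 3-hydroxyphenyl alongside furan-2-yl or thiophen-3-yl remains open, so the effect of the hydroxyl's position may hold only alongside pyridin-2-yl. From the compounds shown here alone, it is also open whether the hydroxyl itself is needed at this place, since a phenyl ring carrying an amine or a methoxy group instead would be required to test that.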